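This account rests on a few compounds, and the source may have more. Where it says the series, first, only, none or still open, it means among the compounds named here.

Three benzylpurines carrying a chloromethyl group on the benzyl ring have been measured. In a functional assay on A498 cells (Homo sapiens) for cytotoxicity, read by sulforhodamine B assay, with a stated time of 48 h (on this read-out higher numbers stand for weaker inhibition of growth and lower numbers for stronger inhibition of growth), compound 1 `Nc1nc(Cl)c2ncn(Cc3ccc(CCl)cc3)c2n1` gives 85100 nM, compound 2 `ClCc1cccc(Cn2cnc3nc(Cl)nc(Cl)c32)c1` gives 2810 nM, and compound 3 `ClCc1ccccc1Cn1cnc2nc(Cl)nc(Cl)c21` gives 5880 nM. Compound 2 stands at the lowest of the three numbers: its nearest neighbour is compound 3, whose number is higher by a margin beyond the scatter, and its furthest is compound 1, whose number is far higher still. Compound 2 is therefore the strongest inhibitor of growth among the three measured in this assay.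

The step considered next leads from compound 2 to compound 4 `ClCc1cccc(Cn2cnc3ncnc(Cl)c32)c1`, which has not yet been measured in this assay. The two structures differ in one place: hydrogen in place of chloro on an aromatic carbon. The chloro group that leaves sits on an aromatic carbon of a six-membered aromatic ring with 2 nitrogen within the fused core, while the other chloro group and the chloromethylbenzyl arm are kept. Within the data shown here, no pair of measured compounds shows this exact change, so the size of the step has to be estimated from compound 2 alone. A small loss of potency is expected, with the step of a 1.8-fold higher number from compound 2 to compound 4 (0.25 log units; within the scatter) judged likely to fall near or slightly beyond the scatter. Compound 4 is accordingly expected to give about 5000 nM in this assay, within a range of 1500 nM to 16000 nM.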

Compound 4, concentration for total growth inhibition: 36300 nM
For compound 4 the middle estimate is 7.3-fold (0.86 log units) below the measured one; the measured number lies above the stated range.
By their numbers in this assay, from the lowest: compound 2; then compound 3; then compound 4; then compound 1.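

Replacing the chloro group on the aromatic carbon between two ring nitrogen atoms with hydrogen gives, in this assay, a 13-fold higher number from compound 2 to compound 4 (1.11 log units; beyond the scatter), a large step that shows inhibition of growth in this setting depends strongly on this one substituent. The earlier compounds shown here could not show this, as no measured pair differed in this place alone, whereas compound 2 and compound 4 keep the other chloro group and the chloromethylbenzyl arm, so the whole step belongs to this single change. Nothing among the compounds shown gives a measured property that bears on the size of this step.

As far as these compounds go, it remains open whether this position needs chloro in particular or would accept another group, such as fluoro, methyl or methoxy, in the setting of compound 2. From the compounds shown here alone, it is also open whether the same change would have a step of similar size with the chloromethyl group placed as in compound 3, and how much the other chloro group contributes when it gives way to hydrogen.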